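Antiproliferative notes on a thiazole-fused series

This account rests on a few compounds, and the source may have more. Where it says the series, first, only, none or still open, it means among the compounds named here.

Measured compounds:
- compound 1, `CCOC(=O)c1csc2nc(CN3CCN(Cc4ccccc4)CC3)c(-c3ccc(OC)cc3)n12`: in a functional assay on HepG2 cells (Homo sapiens) for antiproliferative activity, read by MTT assay, with a stated time of 72 h (a higher number here means a weaker inhibitor, a lower number a stronger inhibitor), compound 1 gives 26400 nM
- compound 2, `CCOC(=O)c1csc2nc(CN3CCN(Cc4ccccc4)CC3)c(-c3ccc(Br)cc3)n12`: in this assay compound 2 gives 47300 nM
- compound 3, `COc1ccc(-c2c(CN3CCCCC3)nc3scc(C(=O)O)n23)cc1`: in this assay compound 3 gives 75100 nM

Compound 1 and compound 2 share a core and differ in one place, (bromo in place of methoxy on an aromatic carbon). The step of a 1.8-fold higher number from compound 1 to compound 2 (0.25 log units; within the scatter) is small and does not separate the two compounds. Compound 3 carries a different core; how it differs from compound 1 is not broken down here. Its value sits within the scatter of compound 2, while against compound 1 the gap is beyond the scatter, so compound 3 reads as weaker than compound 1 only.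

Compound 4, `O=C(O)c1csc2nc(CN3CCCCC3)c(-c3ccc(Br)cc3)n12`, is not yet measured. It differs from compound 3 by bromo in place of methoxy on an aromatic carbon. This is the same change as that from compound 1 to compound 2, made on the core of compound 3. Among the compounds with values here, only one earlier instance of this change is available, and it produced a step within the scatter, so the expected step here is taken as similar in size and direction. For compound 4 the expected step is a 1.5-fold higher number from compound 3 to compound 4 (0.19 log units; within the scatter). This rests on compound 3 at 75100 nM together with the step of a 1.8-fold higher number from compound 1 to compound 2 (0.25 log units; within the scatter). In this assay compound 4 is therefore expected near 115000 nM, with an estimated range from 45000 nM to 290000 nM.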

Compound 4, half-maximal inhibitory concentration: > 100000 nM
Compound 4 gave a limit, no number; the forecaster's own chance of this, stated with the estimate: 30%; the middle value does not contradict the limit.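

In this assay compound 4 gives > 100000 nM, which is a limit of the assay and not a number. The change from 4-methoxyphenyl to 4-bromophenyl on the core of compound 3 can therefore be read only as a floor, with no upper bound on its size: an at least 1.3-fold higher number from compound 3 to compound 4 (0.12 log units; that floor lies within the scatter). Set beside the earlier step on the core of compound 1, this neither shows that the change carries over from one core to the other with the same size nor shows that the two cores respond to it differently: the same change on two cores in this assay, a 1.8-fold higher number (0.25 log units; within the scatter) from compound 1 to compound 2 and an at least 1.3-fold higher number (0.12 log units; that floor lies within the scatter) from compound 3 to compound 4; the limit leaves it open whether they differ.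

The ethyl ester of compounds 1 and 2 and the carboxylic acid of compounds 3 and 4 come with different amine side chains, so the compounds shown do not separate what each of these two places contributes in this assay. Also open, on these data alone, is how other groups would read at the same place on the aromatic ring, for example fluoro, an amine or a carboxylic acid in place of bromo or methoxy, and whether an amide at the position of the ester or acid would fit the same picture.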